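The source may hold more compounds than are shown below. What is called first, only, known or untested is meant among the compounds shown, and "the series" means these compounds.

Working notes on the series in a functional assay on Caco-2 cells (Homo sapiens) for antiproliferative activity, read by MTT assay, with a stated time of 48 h; a higher number here means a weaker inhibitor, a lower number a stronger inhibitor. Compound 1 `CCn1c(C(=O)NCCN)ccc1C(CC)(CC)c1ccc(OCCC(O)(CC)CC)c(C)c1` gives 1740 nM.

Compound 2 `C=CCN(C)C(=O)c1ccc(C(CC)(CC)c2ccc(OCCC(O)(CC)CC)c(C)c2)n1CC` gives > 50000 nM, which is a limit of this assay and not a number. Compound 2 therefore stands at the limit of > 50000 nM in this assay, at which 1 of the 2 values shown sits.

Compound 3 `C#CC(C)OC(=O)c1ccc(C(CC)(CC)c2ccc(OCCC(O)(CC)CC)c(C)c2)n1CC` keeps the shared core and differs from compound 2 at one place: (1-methylprop-2-yn-1-yl)oxy in place of allyl(methyl)amino on a carbonyl carbon. In words, this is (1-methylprop-2-yn-1-yl)oxy in place of allyl(methyl)amino on a carbonyl carbon.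

Within the data shown here, only one measured step bears on this, and it bears loosely: an at least 28-fold higher number from compound 1 to compound 2 (1.45 log units; beyond the scatter). That step is large and beyond the scatter, and it acts on the same carbonyl carbon but with a different outgoing group. Compound 3 lacks the (2-aminoethyl)amino group, as compound 2 does, so on that step alone compound 3 is expected to remain much nearer compound 2 than compound 1. No large move is expected, and any measurable change would be toward a lower number.

The expected step is an at least 2.0-fold lower number from compound 2 to compound 3 (0.30 log units; that floor lies within the scatter).

For compound 3 the estimated value is 25000 nM, with an expected range of 5000 nM to 50000 nM.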

Compound 3, half-maximal inhibitory concentration: > 50000 nM
Compound 3 gave a limit, no number; the forecaster's own chance of this, stated with the estimate: 50%; at least 2.0-fold (0.30 log units) between middle value and limit.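

In this assay, replacing (2-aminoethyl)amino on the carbonyl carbon with (1-methylprop-2-yn-1-yl)oxy gives an at least 28-fold higher number from compound 1 to compound 3 (1.45 log units; beyond the scatter), so the large loss is no longer tied to allyl(methyl)amino alone. Two replacement groups, one attached through nitrogen and the other through oxygen, now both end at the same limit of the assay rather than at a number: the limit of > 50000 nM in this assay, at which 2 of the 3 values shown sit. The step from compound 2 to compound 3 cannot be read because both values are limits, so the change from allyl(methyl)amino to (1-methylprop-2-yn-1-yl)oxy cannot be given a direction or a size, and no order can be set between these two groups.

The compounds shown leave open whether the terminal amine of the (2-aminoethyl)amino group, the amide hydrogen or the two-carbon chain is what separates compound 1 from the compounds at the limit. As far as these compounds go, it also remains open whether a 3-aminopropyl amide, a 2-(dimethylamino)ethyl amide or a carboxylic acid on this carbonyl carbon would give a measurable value in this assay, where compound 1 gives 1740 nM.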